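A few compounds are considered here, and "the series" means these few. Any claim that something is new, unique, unknown or untested is made for them only; others in the source may bear on it.

Compound 1 `COc1ccc([C@H]2CC(=O)N(Cc3cccc(N)c3)C2)cc1OC1CCCC1` carries a 3-aminobenzyl group on the amide-type nitrogen of its five-membered ring. In a functional assay on HEK293 cells (Homo sapiens) for cytotoxicity (a lower number here means that less compound is tolerated, a higher number that more compound is tolerated), compound 1 gives > 10000 nM, which is a limit of the assay rather than a measured number. Compound 2 `COc1ccc([C@H]2CC(=O)N(C(=O)c3ccccc3)C2)cc1OC1CCCC1` stands at > 10000 nM, again only a limit. Compound 3 `COc1ccc([C@H]2CC(=O)N(c3cccc(C#N)c3)C2)cc1OC1CCCC1` likewise gives > 10000 nM, a limit. Because of the limit of > 10000 nM in this assay, at which 3 of the 3 values shown sit, none of the steps among these three can be read: a step that the two limits leave unreadable from compound 1 to compound 2, a step that the two limits leave unreadable from compound 1 to compound 3 and a step that the two limits leave unreadable from compound 2 to compound 3 all remain of unknown size.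

Compound 4 `COc1ccc([C@H]2CC(=O)N(c3cccnc3)C2)cc1OC1CCCC1` differs from compound 1 in one place: pyridin-3-yl in place of 3-aminobenzyl on an amide-type nitrogen in a ring. The three measured steps bear on this change only in that each swap of the group on the amide-type nitrogen in a ring has so far left the compound at the same limit. No direction or size of step can be drawn from them. The expectation for compound 4 is therefore another limit, a step that the limit leaves unreadable from compound 1 to compound 4 that amounts to none beyond the scatter. Compound 4 is estimated at 15000 nM, in a range from 5000 nM to 50000 nM.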

Compound 4, half-maximal cytotoxic concentration: > 10000 nM
Compound 4 was reported as a limit; the forecaster's own chance of this, stated with the estimate: 80%; the middle value is on the limit's open side.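

Within the data shown here, no step from compound 1, compound 2 or compound 3 to compound 4 can be read, because all four compounds share one limit: the limit of > 10000 nM in this assay, at which 4 of the 4 values shown sit. Going by these compounds, whether these groups on the amide-type nitrogen in a ring differ at all in this assay stays open.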